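A few compounds are considered here, and "the series" means these few. Any claim that something is new, unique, unknown or untested is made for them only; others in the source may bear on it.

Working notes on the series. Of the compounds shown here, two have been measured. Compound 1 `Cn1ccc2cc(C#Cc3c(F)cccc3F)ccc21` gives 3% in a functional assay on LS174T cells (Homo sapiens) for inhibition, with a stated time of 4 days, tested at 100 nM; a higher number here means a stronger effect of the compound at the concentration tested, a lower number a weaker effect. Compound 2 `Fc1cccc(F)c1C#Cc1cnc2ccccc2c1` gives 0% in this assay. Compound 2 and compound 1 sit together near the floor of the scale, separated by a gap within the usual scatter, so neither stands apart from the other.

Compound 3 `Fc1cccc(F)c1C#Cc1cnc2ccccc2c1Cl` is not yet measured. It differs from compound 2 by chloro in place of hydrogen on an aromatic carbon. Among the compounds with values here, no measured pair in the set shows what such a change does here, so the expected step from compound 2 to compound 3 in this assay is small, a number 5 percentage points higher from compound 2 to compound 3 (within the scatter), none beyond the scatter. For compound 3 the estimated reading in this assay is 5%, within a range of 0% to 20%.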

Compound 3, a percentage reported as inhibition, at one concentration (the size of the read-out at that concentration, not a potency): 0%
Beside the measured number, compound 3's estimate is 5 percentage points above it, and the stated range covers the measured number.
By their numbers in this assay, from the lowest: compounds 2, 3 and 1 (each within the scatter of the next).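

In this assay, chloro in place of hydrogen on an aromatic carbon, ortho to a large group and opposite the ring nitrogen, gives no change at the digits printed from compound 2 to compound 3 (within the scatter). Within the data shown here, this is the first step read: chloro at this position raises nothing at the concentration tested, but with compound 2 already near the floor of the scale, the step cannot show whether the change would lower a reading. No data on hand bear on the reason for this result.

Going by these compounds, it remains open whether an amine or a methoxy group at the same position would lift the reading beyond the scatter. Also open, on these data alone, is whether chloro has any effect on a core that gives a clearly higher reading.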